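A few compounds are considered here, and "the series" means these few. Any claim that something is new, unique, unknown or untested is made for them only; others in the source may bear on it.

Measured in a functional assay on the whole organism for positive allosteric modulation, with Mus musculus as the target; on this read-out higher numbers stand for an effect only at larger amounts of compound and lower numbers for an effect already at smaller amounts:
- compound 1 `CCC(=O)N(c1ccc(OC)cc1)C1CCCC1N(C)C`: > 50 mg/kg; > 50 mg/kg (2 entries)
- compound 2 `CCC(=O)N(c1ccc(C)cc1)C1CCCC1N(C)C`: 10 mg/kg; 10 mg/kg (2 entries)
- compound 3 `CCC(=O)N(c1ccc(Br)cc1)C1CCCC1N(C)C`: > 50 mg/kg

Compound 3 gives > 50 mg/kg, which is a limit of the assay and not a number. Compound 1 gives > 50 mg/kg; > 50 mg/kg (2 entries), also a limit. Only compound 2 gives a number, 10 mg/kg; 10 mg/kg (2 entries).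

Compound 4 `CCC(=O)N(c1ccc([N+](=O)[O-])cc1)C1CCCC1N(C)C` has nitro in place of bromo on an aromatic carbon, para to a large group: nitro in place of bromo on an aromatic carbon. It has not yet been measured in this assay. Among the compounds with values here, no measured step covers this exchange, so no change beyond the scatter is expected from compound 3, and a further report of a limit is the likeliest outcome. This expectation rests on compound 3 at its limit of > 50 mg/kg. Compound 2 at 10 mg/kg; 10 mg/kg (2 entries) goes against it, so a number cannot be ruled out. For compound 4 the estimated value is 50 mg/kg, with an expected range of 20 mg/kg to 100 mg/kg. The expected step is a number no higher from compound 3 to compound 4 (the limit leaves the size open).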

Compound 4, dose for half-maximal effect: 20 mg/kg
For compound 4 the middle estimate is 2.5-fold (0.40 log units) above the measured one; low and high end bracket the measured number.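

The exchange of bromo for nitro on an aromatic carbon, para to a large group, gives an at least 2.5-fold lower number from compound 3 to compound 4 (0.39 log units; beyond the scatter) in this assay. The size of this step stays open because compound 3 stands at a limit: the limit of > 50 mg/kg in this assay, at which 1 of the 4 values shown sits.
A number at this position is thus not confined to methyl: compound 2 gives 10 mg/kg; 10 mg/kg (2 entries) and compound 4, with nitro, gives 20 mg/kg. Compound 1 with methoxy and compound 3 with bromo go against any single trend across the series, as both remain at limits.

Still open, going by these compounds, is how an amine or a carboxylic acid would read at this position. Also open is whether the number for nitro would hold with a longer chain on the carbonyl, since all compounds shown share the same chain.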